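The source may report more compounds than this note shows. Statements on the series, on what has been measured and on what is new or still open speak of the compounds shown alone.

In a functional assay (CEM-VLB cells, Homo sapiens) for antiproliferative activity, read by sulforhodamine B assay, with a stated time of 48 h (a lower number here means a stronger inhibitor, a higher number a weaker inhibitor), compound 1 `O=C1NCCN1c1ccc(S(=O)(=O)Nc2ccc3[nH]ccc3c2)cc1` gives 4840 nM, while compound 2 `Cc1cccc(NS(=O)(=O)c2ccc(N3CCNC3=O)cc2)c1` gives 370 nM. Compound 2 therefore holds the lower of the two actual numbers, and the gap between them lies beyond the usual scatter. Compound 3 `COc1cc(NS(=O)(=O)c2ccc(N3CCNC3=O)cc2)cc(OC)c1OC` gives > 250 nM, which is a limit of the assay and not a number. Compound 4 `O=C1NCCN1c1ccc(S(=O)(=O)Nc2cccc(Br)c2)cc1` differs from compound 2 in one place: bromo in place of methyl on an aromatic carbon. Among the measured compounds shown here, no pair of measured compounds tests this swap, so the expected step of a 1.1-fold lower number from compound 2 to compound 4 (0.02 log units; within the scatter) is none beyond the scatter in this assay. Compound 4 is estimated at 350 nM, with an expected range from 120 nM to 1000 nM.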

Compound 4, half-maximal inhibitory concentration: 250 nM
Compound 4: middle estimate off by 1.4-fold (0.15 log units), on the high side; the range from low to high includes it.
By their numbers in this assay, from the lowest: compounds 4 and 2 (each within the scatter of the next); then compound 1.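

In this assay, putting bromo in place of methyl on this aromatic carbon gives a 1.5-fold lower number from compound 2 to compound 4 (0.17 log units; within the scatter), the only one-place comparison among the compounds shown. Compound 2 and compound 4 therefore cannot be told apart, so at this position, meta to a large group, either group is compatible with activity in this range. Compound 3 has a limit and not a number: the limit of > 250 nM in this assay, at which 1 of the 4 values shown sits.

On these data alone, whether an amine or a carboxylic acid at this position would give a similar number remains open. So does the effect of a longer chain there.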